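The source may report more compounds than this note shows. Statements on the series, on what has been measured and on what is new or still open speak of the compounds shown alone.

Compound 1 `Nc1scc(CN2CCN(c3ccc(F)cc3Cl)CC2)c1C(=O)c1ccc(Cl)cc1` gives -70% in a functional assay on CHO cells with adenosine receptor A1 (Homo sapiens) as the target, read by cAMP accumulation and immunoassay, with a stated time of 6 min, tested at 10 uM; a lower number here means a stronger effect, a higher number a weaker effect of the compound at the concentration tested.
Compound 2 `Nc1scc(CN2CCN(c3ccc(Cl)cc3F)CC2)c1C(=O)c1ccc(Cl)cc1` gives -81% in this assay.
Compound 3 `Nc1scc(CN2CCN(c3ccccc3F)CC2)c1C(=O)c1ccc(Cl)cc1` gives -15% in this assay.

Among these three, compound 2 stands lowest. The step of a number 11 percentage points lower from compound 1 to compound 2 (beyond the scatter) is modest, whereas the step of a number 66 percentage points higher from compound 2 to compound 3 (beyond the scatter) is large. Compound 4 `Nc1scc(CN2CCN(c3c(F)cccc3F)CC2)c1C(=O)c1ccc(Cl)cc1` differs from compound 2 by 2,6-difluorophenyl in place of 4-chloro-2-fluorophenyl on an amine nitrogen in a ring. The chloro leaves here too, as in the step of a number 66 percentage points higher from compound 2 to compound 3 (beyond the scatter) and in the step of a number 55 percentage points higher from compound 1 to compound 3 (beyond the scatter), both of which moved strongly toward a weaker effect. Within the data shown here, a second fluorine enters instead, but no measured pair tests such an addition, so the expectation for compound 4 is a clearly weaker effect, about a number 56 percentage points higher from compound 2 to compound 4 (beyond the scatter). For compound 4 the estimated value in this assay is -25%, within -55% to 5%.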

Compound 4, a percentage reported as activity, at one concentration (the size of the read-out at that concentration, not a potency): -80%
Beside the measured number, compound 4's estimate is 55 percentage points above it; the measured number lies below the stated range.
By their numbers in this assay, from the lowest: compounds 2, 4 and 1 (each within the scatter of the next, the first and the last beyond it); then compound 3.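

Removing chloro does not by itself weaken the effect: adding fluoro to the ring gives a number 65 percentage points lower from compound 3 to compound 4 (beyond the scatter), while a number 1 percentage points higher from compound 2 to compound 4 (within the scatter) and a number 10 percentage points lower from compound 1 to compound 4 (within the scatter). The 2,6-difluorophenyl group thus matches both chloro-bearing rings, so chloro is not required here. Among these four, the compounds with two halogens on the phenyl ring group together and compound 3, with one, stands apart, and no compound goes against this; nothing available explains that difference. Going by these compounds, whether a methyl or methoxy group could replace the second halogen remains open, as does the result for a phenyl ring without halogen.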